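Halogen-to-methyl change on the shared core, toward compound 4

The source may hold more compounds than are shown below. What is called first, only, known or untested is meant among the compounds shown, and "the series" means these compounds.

Measured so far in an assay on isolated protein for inhibition of Amine oxidase [flavin-containing] B (Homo sapiens), read by fluorescence, with a stated time of 15 min; on this read-out higher numbers stand for weaker inhibition and lower numbers for stronger inhibition:
compound 1 `COc1ccc(/C=C/c2cc(OC)cc(OC)c2/C=C/C(=O)c2cc3cc(Br)ccc3oc2=O)cc1` gives only a limit of the assay, > 60000 nM.
compound 2 `COc1ccc(/C=C/c2cc(OC)cc(OC)c2/C=C/C(=O)c2cc3cc(Cl)ccc3oc2=O)cc1` likewise gives only a limit, > 60000 nM.
compound 3 `COc1ccc(/C=C/c2cc(OC)cc(OC)c2/C=C/C(=O)c2cc3cc(F)ccc3oc2=O)cc1` gives a readable number, 10200 nM.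

Compound 1 thus stands at the ceiling of the measurable range; the limit of > 60000 nM in this assay, at which 2 of the 3 values shown sit, holds two of the three values, so compound 1 cannot be ranked against compound 2, and the step that the two limits leave unreadable from compound 1 to compound 2 stays unreadable. The readable steps both run to compound 3: an at least 5.8-fold lower number from compound 1 to compound 3 (0.76 log units; beyond the scatter) and an at least 5.8-fold lower number from compound 2 to compound 3 (0.76 log units; beyond the scatter), each a move from a heavier halogen to fluoro with a number that comes down out of the limit.

Compound 4 `COc1ccc(/C=C/c2cc(OC)cc(OC)c2/C=C/C(=O)c2cc3cccc(C)c3oc2=O)cc1` differs from compound 1 by a group of 12 heavy atoms (10 carbon, 2 oxygen; one six-membered aromatic ring of carbon only, one six-membered aromatic ring with 1 hetero atom) in place of a group of 12 heavy atoms (9 carbon, 2 oxygen, 1 bromine; one six-membered aromatic ring of carbon only, one six-membered aromatic ring with 1 hetero atom), on a carbonyl carbon. Among the compounds with values here, no measured step carries a methyl in, and none removes a halogen without another halogen entering, so the bearing of the three steps is only indirect: the shared core tolerates a smaller substituent with a lower number, as compound 3 shows, but the present change is not the same kind.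

The expectation for compound 4 is therefore a number that may leave the limit, with the step of an at least 1.7-fold lower number from compound 1 to compound 4 (0.23 log units; that floor lies within the scatter), yet the chance of another limit remains large. The estimate for compound 4 is 35000 nM, between 8000 nM and 60000 nM.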

Compound 4, half-maximal inhibitory concentration: 20000 nM
Beside the measured number, compound 4's estimate is 1.8-fold (0.24 log units) above it; measured number inside the range.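

In this assay, compound 4 shows that a readable number on the shared core does not depend on a fluoro group, since a group with no halogen also comes off the limit, with an at least 3.0-fold lower number from compound 1 to compound 4 (0.47 log units; beyond the scatter) and an at least 3.0-fold lower number from compound 2 to compound 4 (0.47 log units; beyond the scatter). Against the only other readable member there is a 2.0-fold higher number from compound 3 to compound 4 (0.29 log units; within the scatter), which lies within the scatter, so this assay does not separate compound 3 from compound 4, and fluoro and methyl-bearing groups cannot be put in order here. The two larger steps give only floors and not true sizes, because compound 1 and compound 2 each stand at a limit: the limit of > 60000 nM in this assay, at which 2 of the 4 values shown sit.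

Going by these compounds, the step between compound 1 and compound 2 still cannot be read, and how far either lies past its limit stays unknown. Whether an amine, a hydroxyl or a longer chain in place of the methyl would move the number beyond the scatter from compound 4 stays open, since every group shown so far is a halogen or a methyl.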